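The compounds below may be only part of what the source reports. "The series", "measured", "known", "first", "only" and "open" are said of these compounds alone.

Measured so far: compound 1 `Cc1cccc(N(C)CC2CCC/C(=C\c3ccccc3)C2=O)c1` gives 46.8%; compound 2 `Cc1ccc(/C=C2\CCCC(CN(C)c3cccc(C)c3)C2=O)cc1` gives 36.2%; compound 3 `COc1ccc(C2(O)/C(=C/c3ccccc3)CCCC2CN(C)c2ccccc2)cc1` gives 38.3%.

All three were tested in a functional assay on the whole organism (strain Wistar) for inhibition, with Rattus norvegicus as the target, read by paw edema, with stated times of 1 h and 3 h, at a dose of 200 mg/kg by the oral route; a higher number here means more inhibition at the dose given (going by the name of the read-out), a lower number less inhibition. Compound 1 and compound 2 share one core; the difference between them is methyl in place of hydrogen on an aromatic carbon, and the step it made is a number 10.6 percentage points lower from compound 1 to compound 2 (beyond the scatter). Compound 3 has a different core, and how it differs from compound 1 is not broken down here. The values of compound 3 and compound 2 lie within the scatter of each other, and so do those of compound 3 and compound 1.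

Compound 4 `COc1ccc(C2(O)/C(=C/c3ccccc3)CCCC2CN(C)c2ccc(C)cc2)cc1` has not been measured. It differs from compound 3 by methyl in place of hydrogen on an aromatic carbon. Going by the values given here, this is the same kind of change as the one from compound 1 to compound 2, though here the ring that takes the methyl is the phenyl of the methyl(phenyl)amino group, not the ring that changed before. Among the compounds with values here, on the earlier step it is estimated that the change from compound 3 to compound 4 in this assay will be a number 8.3 percentage points lower from compound 3 to compound 4 (within the scatter), because the only comparable change seen gave a number 10.6 percentage points lower from compound 1 to compound 2 (beyond the scatter). Compound 4 is thus expected to give 30%, likely between 18% and 42%.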

Compound 4, a percentage reported as inhibition, in the whole organism at one dose (the size of the read-out at that dose, not a potency): 21.3%
The estimate for compound 4 lay 8.7 percentage points above the measured number; measured number inside the range.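

Putting a methyl in place of hydrogen on the core of compound 3 gave a number 17 percentage points lower from compound 3 to compound 4 (beyond the scatter) in this assay. Set beside the earlier step, the change lowers the number on both cores, and the two steps cannot be told apart in size: the same change on two cores in this assay, a number 10.6 percentage points lower (beyond the scatter) from compound 1 to compound 2 and a number 17 percentage points lower (beyond the scatter) from compound 3 to compound 4, 6.4 percentage points apart, within the scatter of two such steps. This supports carrying the expected direction of the change from one core to the other in these two pairs, but two pairs make no rule for the series, the methyl sits on a different ring in each pair, and a reading at one dose says nothing about potency or about why the number falls.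

The compounds shown leave open whether a fluorine, a chlorine or a carboxylic acid in place of the methyl would lower the number in the same way. They also leave open whether the methyl would have the same effect on the same ring in both cores.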